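The source may hold more compounds than are shown below. What is called first, only, known or untested is meant among the compounds shown, and "the series" means these compounds.

In a functional assay on Bel-7402 cells (Homo sapiens) for inhibition, read by MTT assay, with a stated time of 24 h, tested at 0.1 ug/mL (on this read-out lower numbers stand for less inhibition of growth and higher numbers for more inhibition of growth at the one concentration tested), compound 1 `CC(=O)SCCC(CCCCC(=O)O)SC(C)=O` gives 10.3%, compound 2 `Cc1cccc(NC(=O)CCCCC(S)CCS)c1` gives 10.1% and compound 3 `CC(=O)SCCC(CCCCC(=O)Nc1ccccc1Cl)SC(C)=O` gives 6.61%. Compound 3 thus stands within the scatter of both other compounds. Compound 4 `CC(=O)SCCC(CCCCC(=O)Nc1ccc(Cl)cc1)SC(C)=O` has the same atoms as compound 3, joined differently: 4-chlorophenyl in place of 2-chlorophenyl on an amide-type nitrogen. This places 4-chlorophenyl in place of 2-chlorophenyl on an amide-type nitrogen. Among the measured compounds shown here, the one measured step bearing on this change is a number 3.7 percentage points lower from compound 1 to compound 3 (within the scatter), where (2-chlorophenyl)amino replaces hydroxy on a carbonyl carbon. For the measured compounds named here, no measured pair compares the two chlorophenyl groups directly, so no change beyond the scatter is expected in this assay. The expected step is a number 1.4 percentage points higher from compound 3 to compound 4 (within the scatter). For compound 4 the estimated value is 8%, with an expected range from 2% to 17%.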

Compound 4, percent growth inhibition at one concentration: 9.96%
For compound 4 the middle estimate is 2 percentage points below the measured one; the range from low to high includes it.
By their numbers in this assay, from the lowest: compounds 3, 4, 2 and 1 (each within the scatter of the next).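

The direct comparison on the amide-type nitrogen, 4-chlorophenyl in place of 2-chlorophenyl in this assay, gives a number 3.4 percentage points higher from compound 3 to compound 4 (within the scatter) and so separates neither group from the other. Turning the acid into the amide that carries the 4-chlorophenyl group gives a number 0.3 percentage points lower from compound 1 to compound 4 (within the scatter) and, like the 2-chlorophenyl group before it, leaves the number within the scatter of the acid. No available evidence bears on this result. The compounds shown leave open whether an unsubstituted phenyl, a 4-methoxyphenyl or a pyridine ring on that same nitrogen would move the number beyond the scatter.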